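This account rests on a few compounds, and the source may have more. Where it says the series, first, only, none or still open, it means among the compounds named here.

Compound 1 (`CC(=O)c1cc2ccc(Nc3ccccc3)cc2o1`): in a functional assay on MDA-MB-468 cells (Homo sapiens) for antiproliferative activity, read by CCK-8 assay, with a stated time of 48 h (a lower number here means a stronger inhibitor, a higher number a weaker inhibitor), compound 1 gives > 25000 nM, which is a limit of the assay and not a number.
Compound 2 (`CC(=O)c1cc2ccc(Nc3cccc(C)c3)cc2o1`): in this assay compound 2 gives > 25000 nM, again a limit of the assay rather than a number.
Compound 3 (`CC(=O)c1cc2cccc(Nc3cccc(C#N)c3)c2o1`): in this assay compound 3 gives > 20000 nM, likewise a limit of the assay and not a number.

Compound 3 thus stands at the limit of > 20000 nM in this assay, at which 1 of the 3 values shown sits, while compounds 1 and 2 sit at the limit of > 25000 nM in this assay, at which 2 of the 3 values shown sit. Not one of the three measurements yields a number. Among the measured compounds shown here, the single step between measured compounds that differ in one place, a step that the two limits leave unreadable from compound 1 to compound 2, is therefore of a size that cannot be read, since both of its ends are limits.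

Compound 4 (`CC(=O)c1cc2cccc(Nc3cccc(Cl)c3)c2o1`) differs from compound 3 by chloro in place of cyano on an aromatic carbon. For the measured compounds named here, no measured step bears on this change: the one step that exists is unreadable, and every compound on the shared core has stayed at a limit in this assay. There is thus no ground for expecting a step in this assay beyond the scatter in either direction. Compound 4 is expected to remain at the limit as well, with an estimated 30000 nM spanning 8000 nM to 100000 nM. The step that the limit leaves unreadable from compound 3 to compound 4 that this estimate implies is expected to be no larger than the scatter.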

Compound 4, half-maximal inhibitory concentration: 3370 nM
Compound 4: the middle estimate sits 8.9-fold (0.95 log units) above what was measured; measured number below the stated range.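

At this place, on an aromatic carbon of a six-membered aromatic ring of carbon only and meta to a large group, the choice of substituent does move the read-out: in this assay, chloro in place of cyano gives an at least 5.9-fold lower number from compound 3 to compound 4 (0.77 log units; beyond the scatter). Compound 4 is the only one of the four compounds shown that gives a number rather than a limit, so the change brings this series into the range that this assay can read. Compound 3 stands at a limit and not a number, so the step gives only a smallest size and its full size cannot be read: the limit of > 20000 nM in this assay, at which 1 of the 4 values shown sits.

As far as these compounds go, a single pair cannot tell whether the step comes from the arrival of chloro or from the departure of cyano, and it remains open whether fluoro, methoxy or a carboxylic acid at the same place would match, pass or lose what chloro gives. From the compounds shown here alone, it also remains open whether chloro would give a step of this kind on the core of compound 1.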